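A Methoxymethyl Variant of Compound 1 Awaits Its Reading

This account rests on a few compounds, and the source may have more. Where it says the series, first, only, none or still open, it means among the compounds named here.

Among the compounds with values here, compound 1 `COc1c(F)c(N)c2c(=O)cc(-c3ccc(N)c(F)c3)oc2c1F` is one of three compounds so far read in a functional assay on MCF7 cells (Homo sapiens) for cytotoxicity, read by neutral red uptake, with a stated time of 3 days (on this read-out lower numbers stand for stronger inhibition and higher numbers for weaker inhibition), where compound 1 gives 100 nM. Among these three numbers, that of compound 1 stands second highest. Compound 2 `Nc1ccc(-c2cc(=O)c3c(N)c(F)c(Cl)c(F)c3o2)cc1F` carries chloro in place of methoxy on an aromatic carbon and gives 210 nM, a step of a 2.1-fold higher number from compound 1 to compound 2 (0.32 log units; beyond the scatter). Compound 3 `CN(C)CCCC(=O)OCc1c(F)c(N)c2c(=O)cc(-c3ccc(N)c(F)c3)oc2c1F` carries (((3-(dimethylamino)propyl)carbonyl)oxy)methyl in place of methoxy on an aromatic carbon and gives 29 nM, a step of a 3.4-fold lower number from compound 1 to compound 3 (0.54 log units; beyond the scatter); between the two substituted compounds the step is a 7.2-fold lower number from compound 2 to compound 3 (0.86 log units; beyond the scatter).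

Compound 4 `COCc1c(F)c(N)c2c(=O)cc(-c3ccc(N)c(F)c3)oc2c1F` has not yet been measured. It differs from compound 1 as follows: methoxymethyl in place of methoxy on an aromatic carbon. Both measured changes at this same aromatic carbon moved the number beyond the scatter, in opposite directions, and the change to methoxymethyl is smaller than either of them. Because a 3.4-fold lower number from compound 1 to compound 3 (0.54 log units; beyond the scatter) shows a lower number when a larger oxygen-bearing group replaces methoxy here, a small step toward a lower number is expected for compound 4, though one that may well stay within the scatter. For compound 4 in this assay the estimate is 70 nM, with a range from 30 nM to 160 nM. This corresponds to an expected step of a 1.4-fold lower number from compound 1 to compound 4 (0.15 log units; within the scatter).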

Compound 4, half-maximal inhibitory concentration: 46 nM
Estimate against measurement, compound 4: 1.5-fold (0.18 log units) above, within the range that was stated.
By their numbers in this assay, from the lowest: compounds 3 and 4 (each within the scatter of the next); then compound 1; then compound 2.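

In this assay the change from methoxy to methoxymethyl on this aromatic carbon is a readable step on its own, a 2.2-fold lower number from compound 1 to compound 4 (0.34 log units; beyond the scatter), so the long ester chain of compound 3 is not required for a number lower than that of compound 1. Replacing the (3-(dimethylamino)propyl)carbonyl on the oxygen with methyl gives a 1.6-fold higher number from compound 3 to compound 4 (0.20 log units; within the scatter), which leaves compound 3 and compound 4 indistinguishable in this assay and shows that the dimethylamino-bearing chain adds no readable difference over methoxymethyl. Measured against chloro at the same carbon, the change gives a 4.6-fold lower number from compound 2 to compound 4 (0.66 log units; beyond the scatter), so methoxymethyl and the ester group both lie on the same side of compound 1, with chloro on the other.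

No measurement is available to explain why methoxymethyl and methoxy differ at this carbon. From the compounds shown here alone, whether hydroxymethyl, aminomethyl, a carboxylic acid or a longer ether chain on this carbon would give a number like that of compound 4 remains open, as does whether the steps seen here would hold on cells other than MCF7.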